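Swapping cyclopropylmethyl for phenyl on compound 2

This account rests on a few compounds, and the source may have more. Where it says the series, first, only, none or still open, it means among the compounds named here.

Measured so far in an ADME assay on liver for metabolic stability, with Liver microsome (Homo sapiens) as the target, read by LC-MS, using microsomes; a higher number here means faster removal of the compound, a lower number slower removal:
- compound 1 `O=C(NCc1cc(Cl)ccc1-n1cnnn1)[C@@H]1C[C@@H]2C[C@@H]2N1C(=O)[C@H](O)CC1CC1`: < 12 mL.min-1.g-1, a limit of the assay and not a number
- compound 2 `O=C(NCc1cc(Cl)ccc1-n1cnnn1)[C@@H]1C[C@H]2C[C@H]2N1C(=O)[C@H](O)CC1CC1`: 25 mL.min-1.g-1

Within the data shown here, compound 2, at 25 mL.min-1.g-1, holds the only actual number in this assay. The other result is a limit.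

Compound 3 `O=C(NCc1cc(Cl)ccc1-n1cnnn1)[C@@H]1C[C@H]2C[C@H]2N1C(=O)[C@H](O)c1ccccc1` has one change from compound 2: phenyl in place of cyclopropylmethyl on a saturated chain carbon bound to a carbonyl carbon and an oxygen on a saturated carbon.

Among the measured compounds shown here, the one measured step is an at least 2.0-fold higher number from compound 1 to compound 2 (0.31 log units; beyond the scatter). Going by these compounds, its true size stays open because of the limit of < 12 mL.min-1.g-1 in this assay, at which 1 of the 2 values shown sits. It also comes with the fact that compounds 1 and 2 differ only in the configuration as drawn, so it shows that this read-out can respond to a small structural difference but gives no direct guide to exchanging one group for another. For the measured compounds named here, no measured step involves this group, so the expectation starts from compound 2 at 25 mL.min-1.g-1, with a wide margin on both sides. The expected step is a 1.3-fold lower number from compound 2 to compound 3 (0.10 log units; within the scatter), and no move beyond the scatter is expected in either direction. For compound 3 the estimate is 20 mL.min-1.g-1, with an expected range from 9 mL.min-1.g-1 to 45 mL.min-1.g-1.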

Compound 3, intrinsic clearance in microsomes: < 15 mL.min-1.g-1
Compound 3 was reported as a limit; the forecaster's own chance of this, stated with the estimate: 25%; middle value at least 1.3-fold (0.12 log units) away from the limit.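

In this assay, putting phenyl in place of cyclopropylmethyl on a saturated chain carbon bound to a carbonyl carbon and an oxygen on a saturated carbon gives an at least 1.6-fold lower number from compound 2 to compound 3 (0.22 log units; that floor lies within the scatter). This is the first step shown that exchanges one group for another rather than changing only the configuration as drawn, and it shows that an aromatic ring at this place does not raise the read-out above that of compound 2. Whether the true step goes beyond the usual scatter cannot be told, because the result for compound 3 is a limit of the assay and not a number: the limit of < 15 mL.min-1.g-1 in this assay, at which 1 of the 3 values shown sits.

The compounds shown leave open how the read-out responds to other groups at this place, such as a pyridine ring, a plain methyl or a longer chain ending in an amine. They also leave open whether phenyl gives a similar result with the configuration as drawn in compound 1, which is likewise reported only as a limit.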